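Notes on the sulfonamide nitrogen aryl group

A few compounds are considered here, and "the series" means these few. Any claim that something is new, unique, unknown or untested is made for them only; others in the source may bear on it.

Values in a functional assay on MCF7 cells (Homo sapiens) for antiproliferative activity, read by sulforhodamine B assay, with a stated time of 48 h; on this read-out higher numbers stand for weaker inhibition and lower numbers for stronger inhibition:
- compound 1 `Cc1ccc(NS(=O)(=O)c2ccc(N3CCNC3=O)cc2)cc1`: 610 nM
- compound 2 `Cc1cc(C)cc(NS(=O)(=O)c2ccc(N3CCNC3=O)cc2)c1`: 100 nM

Among the compounds with values here, compound 2 holds the lower of the two numbers so far, at 100 nM. The next structure is compound 3 `O=C1NCCN1c1ccc(S(=O)(=O)Nc2ccc(Cl)cc2)cc1`, with 4-chlorophenyl in place of 3,5-dimethylphenyl on a sulfonamide nitrogen. Within the data shown here, one measured step bears on this change, at the same place: a 6.1-fold lower number from compound 1 to compound 2 (0.79 log units; beyond the scatter), modest and beyond the scatter. Among the measured compounds shown here, the entering 4-chlorophenyl resembles the 4-methylphenyl of compound 1 more than the leaving group, although no measured compound carries chlorine. A step of similar size or somewhat smaller, toward a higher number in this assay, is therefore expected. The estimated step is a 4.5-fold higher number from compound 2 to compound 3 (0.65 log units; beyond the scatter). The expected value for compound 3 is 450 nM, with an estimated range of 150 nM to 1400 nM.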

Compound 3, half-maximal inhibitory concentration: 170 nM
Beside the measured number, compound 3's estimate is 2.6-fold (0.42 log units) above it; low and high end bracket the measured number.
By their numbers in this assay, from the lowest: compounds 2 and 3 (each within the scatter of the next); then compound 1.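

In this assay, the 4-chlorophenyl and 3,5-dimethylphenyl groups on the sulfonamide nitrogen cannot be told apart, since a 1.7-fold higher number from compound 2 to compound 3 (0.23 log units; within the scatter) is a difference that stays within the scatter. Chloro in place of methyl on an aromatic carbon gives a 3.6-fold lower number from compound 1 to compound 3 (0.55 log units; beyond the scatter) and this lies beyond the scatter, so among these compounds a phenyl group with a single substituent can reach the level of the 3,5-dimethylphenyl group, and the choice of that substituent matters. The data on hand offer no explanation for either step.

The compounds shown leave open how a 3,5-dichlorophenyl group on the same nitrogen would compare with compound 2 and compound 3. Also open, from the compounds shown here alone, is whether a methoxy or an amino group in place of the chloro of compound 3 would hold the number at this level.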